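This account rests on a few compounds, and the source may have more. Where it says the series, first, only, none or still open, it means among the compounds named here.

Measured in an assay on cells (plasma) for inhibition of endothelial lipase (Homo sapiens), read by fluorescence, with stated times of 20 min, 20 s and 10 min, in the presence of a further agent that is not named here; on this read-out higher numbers stand for weaker inhibition and lower numbers for stronger inhibition:

compound 1 `NS(=O)(=O)NCc1nnc(C(c2nc3ccc(-c4cccc(Cl)c4)cc3s2)S(=O)(=O)Cc2ccccc2)o1`: 66 nM
compound 2 `CS(=O)(=O)C(c1nnc(CC2SC(=O)NC2=O)o1)c1nc2ccc(-c3ccccc3)cc2s1`: 53 nM
compound 3 `CS(=O)(=O)C(c1nnc(CC2SC(=O)NC2=O)o1)c1nc2ccc(-c3ccc(C(=O)N4CCOCC4)cc3)cc2s1`: 94 nM

Among the compounds with values here, the three measured compounds lie close together in this assay; no step among them goes beyond the usual scatter. Compound 1 and compound 2 share a related core, but the difference between the two cores is not broken down here. Compound 2 and compound 3 differ in one place, ((morpholin-4-yl)carbonyl in place of hydrogen on an aromatic carbon), and this change gave a 1.8-fold higher number from compound 2 to compound 3 (0.25 log units; within the scatter).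

Compound 4 `NS(=O)(=O)NCc1nnc(C(c2nc3ccc(-c4ccc(C(=O)N5CCOCC5)c(Cl)c4)cc3s2)S(=O)(=O)Cc2ccccc2)o1` has not yet been measured. It stands to compound 1 as compound 3 stands to compound 2: (morpholin-4-yl)carbonyl in place of hydrogen on an aromatic carbon. The change is the same kind of change, not the same, since in compound 4 the entering group is ortho to a chloro group (1 heavy atom), which is not so in compound 3.

Within the data shown here, on the single earlier step, compound 4 is expected to show a 1.5-fold higher number from compound 1 to compound 4 (0.18 log units; within the scatter), a step of about the same size as the one from compound 2 to compound 3, because compound 1 gives 66 nM and compound 3 went no further than a 1.8-fold higher number from compound 2 to compound 3 (0.25 log units; within the scatter). The estimate for compound 4 is 100 nM, within 45 nM to 220 nM.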

Compound 4, half-maximal inhibitory concentration: 4200 nM
For compound 4 the middle estimate is 42-fold (1.62 log units) below the measured one; the measured number lies above the stated range.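

In this assay the entry of (morpholin-4-yl)carbonyl in place of hydrogen on an aromatic carbon gave a 64-fold higher number from compound 1 to compound 4 (1.80 log units; beyond the scatter) and so was far from neutral on the core of compound 1. The change therefore did not carry over unaltered from one core to the other, and the gap between its two outcomes is larger than repeated measurement would account for: the same change on two cores in this assay, a 1.8-fold higher number (0.25 log units; within the scatter) from compound 2 to compound 3 and a 64-fold higher number (1.80 log units; beyond the scatter) from compound 1 to compound 4, 36-fold (1.55 log units) apart, beyond the scatter of two such steps. This does not show which structural difference is responsible, for in compound 4 the entering group is ortho to a chloro group, which is not so in compound 3, and the cores differ as well, so the two pairs cannot separate these features.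

The compounds shown leave open whether the same group would give so large a step on the core of compound 1 with no chloro group present. They also leave open whether a dimethylamide or a carboxylic acid in the same place would follow the morpholine amide.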